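Working notes: phenylsulfanyl in place of benzoyl

The source may hold more compounds than are shown below. What is called first, only, known or untested is meant among the compounds shown, and "the series" means these compounds.

Measured so far in a functional assay on PC-3 cells (Homo sapiens) for cytotoxicity, read by MTT assay, with a stated time of 72 h, tested at 1 uM; on this read-out lower numbers stand for a stronger effect and higher numbers for a weaker effect at the one concentration tested:
- compound 1, `O=C(Nc1nc2cc(C(=O)c3ccccc3)ccc2[nH]1)OC1COC1`, gives 90.9%
- compound 2, `COC(=O)Nc1nc2cc(C(=O)c3ccccc3N(C)C3COC3)ccc2[nH]1`, gives 101%
- compound 3, `CCCSc1ccc2[nH]c(NC(=O)OCC3(C)COC3)nc2c1`, gives 87.2%

Compound 1 stands second highest of the three numbers. Compound 3 lies nearest, within the usual scatter, so the two read as alike. Compound 2 lies furthest; its number is higher than that of compound 1 by more than the scatter. Among the compounds with values here, all three numbers sit near the top of the scale, so none of the measured compounds shows much effect at the one concentration tested.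

Compound 4, `O=C(Nc1nc2cc(Sc3ccccc3)ccc2[nH]1)OC1COC1`, has not yet been measured. It differs from compound 1 in one place: phenylsulfanyl in place of benzoyl on an aromatic carbon. The shared core of compound 1 and the rest of the molecule are kept. Within the data shown here, no measured pair shows this change directly, so nothing in the numbers so far fixes its size or direction. Given that compound 3 gives a number close to compound 1, little movement is anticipated. The step of a number 2.9 percentage points lower from compound 1 to compound 4 (within the scatter) is expected to be small, most likely within the scatter, with the direction uncertain. For compound 4 the estimate in this assay is 88%, in the range 70% to 105%.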

Compound 4, a percentage reported as activity, at one concentration (the size of the read-out at that concentration, not a potency): 107%
The estimate for compound 4 lay 19 percentage points below the measured number; measured number outside the range, above it.
By their numbers in this assay, from the lowest: compounds 3 and 1 (each within the scatter of the next); then compounds 2 and 4 (each within the scatter of the next).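

In this assay, within the data shown here, phenylsulfanyl in place of benzoyl on this aromatic carbon gives a number 16.1 percentage points higher from compound 1 to compound 4 (beyond the scatter), the first step that can be read as a change in one place. The step lies beyond the scatter and points to a weaker effect at the one concentration tested, so at this position the two groups are not interchangeable, even though each brings one six-membered aromatic ring of carbon only. No measurement at hand accounts for this shift.

This single step does not separate the part played by the carbonyl from that played by the sulfur link, and a phenoxy or phenylamino group at the same place would bear on that question. It also leaves open whether the same step would appear with the rest of the molecule changed.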